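The source may report more compounds than this note shows. Statements on the series, on what has been measured and on what is new or still open speak of the compounds shown alone.

The three measured compounds, with their results in a functional assay on the whole organism with Mus musculus as the target, in the maximal electroshock model; a higher number here means that more compound is needed for the effect, a lower number that less compound is needed:

compound 1, `C[C@@H](NCc1ccc(OCc2ccccc2)cc1)C(N)=O`, gives 17.1 mg/kg
compound 2, `C[C@@H](NCc1ccc(Cc2ccccc2)cc1)C(N)=O`, gives 22.5 mg/kg
compound 3, `C[C@@H](NCc1ccc(CCc2ccccc2)cc1)C(N)=O`, gives 17.8 mg/kg

Compound 1 and compound 2 differ in more than one place, so the difference between the two cores is not broken down here. Compound 2 and compound 3 differ in a single place, (benzyl in place of phenyl on a saturated chain carbon bound to an aromatic carbon), and that change gave a 1.3-fold lower number from compound 2 to compound 3 (0.10 log units; within the scatter).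

Compound 4, `C[C@@H](NCc1ccc(OCCc2ccccc2)cc1)C(N)=O`, has not yet been measured in this assay. It arises from compound 1 by benzyl in place of phenyl on a saturated chain carbon bound to an oxygen on an aromatic ring. The group that leaves and the group that enters are the same as in the step from compound 2 to compound 3, but the surroundings differ: there the saturated chain carbon is bound to an aromatic carbon, here it is bound to an oxygen on an aromatic ring. It is therefore the same kind of change, not the same change.

Going by the values given here, the step from compound 1 to compound 4 is expected to be a 1.1-fold lower number from compound 1 to compound 4 (0.06 log units; within the scatter), because a 1.3-fold lower number from compound 2 to compound 3 (0.10 log units; within the scatter) stayed within the usual scatter, and only this one example of the change is available. For compound 4 the estimate is 15 mg/kg, expected to fall between 8 mg/kg and 30 mg/kg.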

Compound 4, dose for half-maximal effect: 12.2 mg/kg
Compound 4: the middle estimate sits 1.2-fold (0.09 log units) above what was measured; the measured number falls inside the stated range.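

In this assay the exchange of phenyl for benzyl on the saturated chain carbon bound to an oxygen on an aromatic ring gave a 1.4-fold lower number from compound 1 to compound 4 (0.15 log units; within the scatter) and so is too small to read as a real change on its own. Set beside the earlier example, the same exchange behaved alike on the two cores: the same change on two cores in this assay, a 1.3-fold lower number (0.10 log units; within the scatter) from compound 2 to compound 3 and a 1.4-fold lower number (0.15 log units; within the scatter) from compound 1 to compound 4, 1.1-fold (0.04 log units) apart, within the scatter of two such steps

So on these two cores the exchange carried over with no visible difference. Neither step rises above the scatter. Going by these compounds alone, this agreement shows only that the change did little on either core, not that it brings a real gain or that it would behave the same way on a further core.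

What a longer chain in place of benzyl would do remains open, as the compounds shown stop at benzyl. Also open, from the compounds shown here alone, is whether a carboxylic acid in place of the amide would leave the number in the same range.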